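The source may hold more compounds than are shown below. What is called first, only, known or untested is meant among the compounds shown, and "the series" means these compounds.

Compound 1 `CCn1c(C(=O)NCC(=O)OC)ccc1C(CC)(CC)c1ccc(OCS(=O)(=O)c2ccccc2)c(C)c1` in a functional assay on PC-3 cells (Homo sapiens) for antiproliferative activity, read by MTT assay, with a stated time of 24 h (on this read-out lower numbers stand for stronger inhibition and higher numbers for weaker inhibition), gives only a limit, > 50000 nM. Compound 1 therefore stands at the limit of > 50000 nM in this assay, at which 1 of the 2 values shown sits, with no number of its own to place it. Compound 3 `CCn1c(C(=O)N[C@@H](CO)CCCO)ccc1C(CC)(CC)c1ccc(OCS(=O)(=O)c2ccccc2)c(C)c1` differs from compound 1 by a group of 7 heavy atoms (5 carbon, 2 oxygen; no ring) in place of a group of 5 heavy atoms (3 carbon, 2 oxygen; no ring), on an amide-type nitrogen. For the measured compounds named here, the single measured step that bears on this change leads to compound 2 `CCn1c(C(=O)N[C@@H](CO)C(C)C)ccc1C(CC)(CC)c1ccc(OCS(=O)(=O)c2ccccc2)c(C)c1`, which in this assay gives 10600 nM, and it was an at least 4.7-fold lower number from compound 1 to compound 2 (0.67 log units; beyond the scatter); there too the (methoxycarbonyl)methyl on the amide-type nitrogen was replaced. A step of comparable size, toward lower numbers, is therefore expected, as an at least 3.3-fold lower number from compound 1 to compound 3 (0.52 log units; beyond the scatter). Compound 3 is accordingly estimated at 15000 nM, within 5000 nM to 50000 nM.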

Compound 3, half-maximal inhibitory concentration: 13400 nM
Compound 3: middle estimate off by 1.1-fold (0.05 log units), on the high side; low and high end bracket the measured number.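

On the amide-type nitrogen, a second replacement of (methoxycarbonyl)methyl also brings a measured number in this assay (an at least 3.7-fold lower number from compound 1 to compound 3 (0.57 log units; beyond the scatter)). On the saturated chain carbon, 3-hydroxypropyl and isopropyl do not separate (a 1.3-fold higher number from compound 2 to compound 3 (0.10 log units; within the scatter)), so this read-out does not distinguish the two chains. Compound 1 remains a limit of the assay, so the first step has no exact size: the limit of > 50000 nM in this assay, at which 1 of the 3 values shown sits.

From the compounds shown here alone, whether an amine, a carboxylic acid or a longer chain on that saturated chain carbon would move the number beyond the scatter remains open.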